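Series notes: chloro for methoxy on the pendant aryl

A few compounds are considered here, and "the series" means these few. Any claim that something is new, unique, unknown or untested is made for them only; others in the source may bear on it.

Compound 3 `CCOC(=O)c1cnc(-c2ccc(OC)cc2)nc1NN1C(=O)C=C(C)C1=O` gives the lowest number of the three in a functional assay on Jurkat cells for inhibition of nuclear factor NF-kappa-B complex (Homo sapiens) (on this read-out higher numbers stand for weaker inhibition and lower numbers for stronger inhibition), with 900 nM. Compound 1 `CCOC(=O)c1cnc(C(F)(F)F)nc1NN1C(=O)C=C(C)C1=O` gives 1000 nM and compound 2 `CCOC(=O)c1cnc(C)nc1NN1C(=O)C=C(C)C1=O` gives 16000 nM. The gap a 1.1-fold lower number from compound 1 to compound 3 (0.05 log units; within the scatter) lies within the scatter, whereas an 18-fold lower number from compound 2 to compound 3 (1.25 log units; beyond the scatter) and a 16-fold higher number from compound 1 to compound 2 (1.20 log units; beyond the scatter) are large. Compound 4 `CCOC(=O)c1cnc(-c2ccc(Cl)cc2)nc1NN1C(=O)C=C(C)C1=O` differs from compound 3 by chloro in place of methoxy on an aromatic carbon. Among the measured compounds shown here, none of the measured steps touches the 4-methoxyphenyl group itself; all three concern the substituent on the core's aromatic carbon, so this exchange has no direct precedent. In this assay the step of no change at the digits printed from compound 3 to compound 4 (within the scatter) is therefore expected, none beyond the scatter. For compound 4 the estimate is 900 nM, ranging from 300 nM to 3000 nM.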

Compound 4, half-maximal inhibitory concentration: 300 nM
Compound 4: middle estimate off by 3.0-fold (0.48 log units), on the high side; measured number inside the range.
By their numbers in this assay, from the lowest: compound 4; then compounds 3 and 1 (each within the scatter of the next); then compound 2.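

In this assay the substituent on the pendant aryl, para to a large group, proves able to move the number: a 3.0-fold lower number from compound 3 to compound 4 (0.48 log units; beyond the scatter) is the first step shown at this place. With 4-chlorophenyl on the core, a 3.3-fold lower number from compound 1 to compound 4 (0.52 log units; beyond the scatter) separates the aryl series from trifluoromethyl, which 4-methoxyphenyl did not do, and a 53-fold lower number from compound 2 to compound 4 (1.73 log units; beyond the scatter) is the widest step in the series. No measurement shown accounts for the chloro result.

Only methoxy and chloro occupy this place, so one pair cannot show what drives the step. From the compounds shown here alone, whether fluoro, a nitrile or an amine there would follow chloro or methoxy stays open.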